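Swapping 3-methylphenyl for 4-chlorophenyl on the amide nitrogen

A few compounds are considered here, and "the series" means these few. Any claim that something is new, unique, unknown or untested is made for them only; others in the source may bear on it.

Measured in a functional assay on T47D cells (Homo sapiens) for inhibition, read by CCK-8 assay, with a stated time of 72 h, tested at 1 uM; on this read-out lower numbers stand for less inhibition of growth and higher numbers for more inhibition of growth at the one concentration tested:
- compound 1 `CN(C)C(=O)c1cc2cnc(Nc3ccc(NC(=O)C4(C(=O)Nc5ccc(F)cc5)CC4)cc3)nc2n1C1CCCC1` gives 74.7%
- compound 2 `Cc1cccc(NC(=O)C2(C(=O)Nc3ccc(Nc4ncc5cc(C(=O)N(C)C)n(C6CCCC6)c5n4)cc3)CC2)c1` gives 45.7%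
- compound 3 `CN(C)C(=O)c1cc2cnc(Nc3ccc(N)cn3)nc2n1C1CCCC1` gives 18.8%

Among these three, compound 2 holds the middle place, with compound 3 lower and compound 1 higher, both gaps beyond the scatter. Compound 4 `CN(C)C(=O)c1cc2cnc(Nc3ccc(NC(=O)C4(C(=O)Nc5ccc(Cl)cc5)CC4)cc3)nc2n1C1CCCC1` follows from compound 2 by one change, 4-chlorophenyl in place of 3-methylphenyl on an amide-type nitrogen. For the measured compounds named here, one measured step bears on this, a number 29 percentage points lower from compound 1 to compound 2 (beyond the scatter), where 3-methylphenyl took the place of 4-fluorophenyl on that nitrogen. Compound 4 removes the same 3-methylphenyl, but it brings 4-chlorophenyl rather than 4-fluorophenyl, so a rise of similar or somewhat smaller size is expected in this assay. The estimated change is a number 22.3 percentage points higher from compound 2 to compound 4 (beyond the scatter). The estimate for compound 4 is 68%, within a range of 50% to 84%.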

Compound 4, percent growth inhibition at one concentration: 22.8%
Beside the measured number, compound 4's estimate is 45.2 percentage points above it; measured number below the stated range.
By their numbers in this assay, from the lowest: compounds 3 and 4 (each within the scatter of the next); then compound 2; then compound 1.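

In this assay the halogen on this ring matters in its own right, with a number 51.9 percentage points lower from compound 1 to compound 4 (beyond the scatter) for nothing more than chloro in place of fluoro on an aromatic carbon. Losing 3-methylphenyl is thus no gain in itself, since 4-chlorophenyl in its place gives a number 22.9 percentage points lower from compound 2 to compound 4 (beyond the scatter) and leaves 4-fluorophenyl clearly first among the three groups on this amide-type nitrogen. Nothing available explains this sharp split between the two halogens.

The compounds shown leave open where an unsubstituted phenyl, a 4-bromophenyl or a 3-fluorophenyl would stand on this nitrogen. They also leave open whether the lead of 4-fluorophenyl would hold at other concentrations.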